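Selenium-linked diacyl amidines: benzyl in place of methyl

The compounds below may be only part of what the source reports. "The series", "measured", "known", "first", "only" and "open" are said of these compounds alone.

Measured so far:
Compound 1, `C[Se]/C(=N\C(=O)c1cc2ccccc2s1)NC(=O)c1cc2ccccc2s1`, in a functional assay on K562 cells (Homo sapiens) for cytotoxicity, read by MTT assay, with a stated time of 72 h (a lower number here means a stronger inhibitor of growth, a higher number a weaker inhibitor of growth), gives 61000 nM.
Compound 2, `C[Se]/C(=N\C(=O)c1ccco1)NC(=O)c1ccco1`, in this assay gives only a limit, > 100000 nM. That reading is the limit of > 100000 nM in this assay, at which 1 of the 3 values shown sits.
Compound 3, `C[Se]/C(=N\C(=O)c1cnc2ccccc2c1)NC(=O)c1cnc2ccccc2c1`, in this assay gives 29900 nM.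

Of the two numbers in hand, compound 3 stands lowest. Compound 1 gives the higher number, and the gap between the two lies beyond the scatter. Compound 2 contributes no number, only its limit.

The next member, compound 4, is `O=C(/N=C(/NC(=O)c1cnc2ccccc2c1)[Se]Cc1ccccc1)c1cnc2ccccc2c1`. It keeps the core of compound 3 and differs only at the selenium substituent: phenyl in place of hydrogen on a saturated chain carbon bound to a selenium atom. Within the data shown here, no pair of measured compounds differs in a single place, so there is no measured step of the same kind to lean on, and the two aromatic amide ends of compound 3 are retained unchanged.

With nothing in the data to point strongly either way, a modest move toward a lower number is expected in this assay, a step from a 1.7-fold lower number from compound 3 to compound 4 (0.22 log units; within the scatter) that could still fall within the scatter. Compound 4 is estimated at 18000 nM in this assay, with a range from 6000 nM to 60000 nM.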

Compound 4, concentration for total growth inhibition: 72600 nM
The estimate for compound 4 lay 4.0-fold (0.61 log units) below the measured number, outside the stated range (above it).
By their numbers in this assay, from the lowest: compound 3; then compounds 1 and 4 (each within the scatter of the next). At a limit, above all of these: compound 2.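

Phenyl in place of hydrogen on a saturated chain carbon bound to a selenium atom gives a 2.4-fold higher number from compound 3 to compound 4 (0.39 log units; beyond the scatter) in this assay, so this position is not silent: with the core of compound 3 held fixed, the change alone moves the number beyond the scatter. Among these compounds, all the earlier compounds carry methyl on selenium and differ at their aromatic amide ends, so they gave no reading of this position, and the first reading here shows that methyl to benzyl does not lower the number on this core. Nothing in hand accounts for the direction or size of this step.

From the compounds shown here alone, whether the same change gives a similar step with the amide ends of compound 1 remains open, as this is a single step on a single core. Also open, going by these compounds, is whether the higher number follows the phenyl ring itself, which an ethyl group, a longer saturated chain, or a chain ending in an amine or a carboxylic acid on selenium would help to separate.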